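Replacing the 4-carboxyphenyl group of compound 2

The source may report more compounds than this note shows. Statements on the series, on what has been measured and on what is new or still open speak of the compounds shown alone.

Measured in a functional assay on SCC-25 cells (Homo sapiens) for antiproliferative activity; on this read-out higher numbers stand for weaker inhibition and lower numbers for stronger inhibition:
- Compound 1 `Nc1nc(N)c2nc(CNc3ccc(C(=O)NC(CCCNC(=O)c4cccc(C(=O)O)c4)C(=O)O)cc3)cnc2n1`: 2.9 nM
- Compound 2 `Nc1nc(N)c2nc(CNc3ccc(C(=O)NC(CCCNC(=O)c4ccc(C(=O)O)cc4)C(=O)O)cc3)cnc2n1`: 72 nM

Of the two measured compounds, compound 2 holds the higher number in this assay, at 72 nM. The next compound, compound 3 `Nc1nc(N)c2nc(CNc3ccc(C(=O)NC(CCCNC(=O)c4ccc(Cl)c(Cl)c4C(=O)O)C(=O)O)cc3)cnc2n1`, changes one group: 2-carboxy-3,4-dichlorophenyl in place of 4-carboxyphenyl on a carbonyl carbon. Among the compounds with values here, only one measured step bears on this change, a 25-fold higher number from compound 1 to compound 2 (1.39 log units; beyond the scatter). That step is large and beyond the scatter, and it came with 4-carboxyphenyl in place of 3-carboxyphenyl on a carbonyl carbon. The group tied to that rise is the one that now leaves. Within the data shown here, no measured compound carries chlorine or a 2-carboxy group, so the size of the change remains uncertain. A large drop, close in size to the measured step, is therefore expected: a 24-fold lower number from compound 2 to compound 3 (1.38 log units; beyond the scatter). Compound 3 is estimated at 3 nM, with an expected range of 0.6 nM to 20 nM.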

Compound 3, half-maximal inhibitory concentration: 18 nM
The estimate for compound 3 lay 6.0-fold (0.78 log units) below the measured number, within the range that was stated.
By their numbers in this assay, from the lowest: compound 1; then compound 3; then compound 2.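

In this assay, the 2-carboxy-3,4-dichlorophenyl group on this carbonyl carbon gives a lower number than the 4-carboxyphenyl group (a 4.0-fold lower number from compound 2 to compound 3 (0.60 log units; beyond the scatter)), so the loss seen with the earlier change is partly recovered. It does not match the 3-carboxyphenyl group (a 6.2-fold higher number from compound 1 to compound 3 (0.79 log units; beyond the scatter)), which keeps the lowest number of the three compounds. No measurement shown here accounts for these differences.

As far as these compounds go, compound 3 differs from compound 2 both in where the carboxylic acid stands and in its two chlorine atoms, so the share of each in the step remains open. From the compounds shown here alone, it also remains open whether a 3-carboxyphenyl group carrying chlorine, or a tetrazole or a primary amide in place of the carboxylic acid, would hold the number of compound 1.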